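The source may hold more compounds than are shown below. What is called first, only, known or untested is meant among the compounds shown, and "the series" means these compounds.

Measured in a toxicity assay on cells (Fibroblast, Homo sapiens) for cytotoxicity; on this read-out lower numbers stand for stronger inhibition and higher numbers for weaker inhibition:
- compound 1 `CC(/C=C/C1=CCCCC1(C)C)=C\C=C\C(C)=C\COC(=O)c1cc(O)c(O)c(O)c1`: 35000 nM
- compound 2 `CC(/C=C/C1=CCCCC1(C)C)=C\C=C\C(C)=C\COC(=O)c1cc(O)ccc1O`: 14000 nM

Among the measured compounds shown here, compound 2, at 14000 nM, holds the lower of the two numbers, and compound 1 is its only neighbour. The next structure is compound 3 `CC(/C=C/C1=CCCCC1(C)C)=C\C=C\C(C)=C\COC(=O)c1ccccc1O`, reached from compound 2 by hydrogen in place of hydroxy on an aromatic carbon. This places hydrogen in place of hydroxy on an aromatic carbon, meta to a large group and para to a hydroxy group.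

For the measured compounds named here, only one measured step bears on this change: a 2.5-fold lower number from compound 1 to compound 2 (0.40 log units; beyond the scatter). That modest step, 2,5-dihydroxyphenyl in place of 3,4,5-trihydroxyphenyl on a carbonyl carbon, also removes a hydroxy group, but it changes the other hydroxy positions as well. It is therefore a loose guide, and a single step establishes no pattern. The data hold no direct measurement of the change from 2,5-dihydroxyphenyl to 2-hydroxyphenyl.

Going by the values given here, a modest move towards a lower number is expected in this assay, no larger than the step from compound 1 to compound 2 and possibly lost in the scatter. The estimated change is a 1.9-fold lower number from compound 2 to compound 3 (0.27 log units; within the scatter). For compound 3 the expected value is 7500 nM, with an estimated range of 3000 nM to 18000 nM.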

Compound 3, half-maximal inhibitory concentration: 150000 nM
Beside the measured number, compound 3's estimate is 20-fold (1.30 log units) below it, and the stated range ends below it.
By their numbers in this assay, from the lowest: compound 2; then compound 1; then compound 3.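

Within this assay, removing the hydroxy group from this aromatic carbon, meta to a large group and para to a hydroxy group, gives an 11-fold higher number from compound 2 to compound 3 (1.03 log units; beyond the scatter), a large step that shows the 2,5-dihydroxyphenyl to 2-hydroxyphenyl change does not continue the earlier modest move towards a lower number. The series also gives a 4.3-fold higher number from compound 1 to compound 3 (0.63 log units; beyond the scatter), which places the 2-hydroxyphenyl ester at the high end of these three numbers, so the count of hydroxy groups alone does not order them: compound 2 sits lowest and goes against any steady trend with the number of hydroxy groups. No measurement at hand accounts for the size of this step.

Still open, on these data alone, is whether the hydroxy group itself is what matters on this aromatic carbon, or whether a methoxy group or an amine there would keep the number near that of compound 2. Also open, as far as these compounds go, is whether the same step holds when the ester is replaced by an amide, or when a carboxylic acid stands on the aromatic ring in place of the hydroxy group.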